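Ortho-Chloro on the Phenoxy Ring of an Acylguanidine Series

A few compounds are considered here, and "the series" means these few. Any claim that something is new, unique, unknown or untested is made for them only; others in the source may bear on it.

Measured compounds:
compound 1 `CCSc1cc(C)c(C(=O)N=C(N)N)cc1S(C)(=O)=O`, 5.9 nM
compound 2 `Cc1cc(Oc2ccccc2)c(S(C)(=O)=O)cc1C(=O)N=C(N)N`, 10 nM

In a functional assay for inhibition of sodium/hydrogen exchanger (Oryctolagus cuniculus) (on this read-out higher numbers stand for weaker inhibition and lower numbers for stronger inhibition), compound 2 gives 10 nM, the higher of the two numbers shown, with compound 1 the nearest at a 1.7-fold higher number from compound 1 to compound 2 (0.23 log units; within the scatter). Compound 3 `Cc1cc(Oc2ccccc2Cl)c(S(C)(=O)=O)cc1C(=O)N=C(N)N` differs from compound 2 by chloro in place of hydrogen on an aromatic carbon. No measured step touches the phenoxy ring itself; the only step shown, a 1.7-fold higher number from compound 1 to compound 2 (0.23 log units; within the scatter), exchanges the whole substituent and stays within the scatter. With nothing to anchor a direction, no step beyond the scatter is expected in this assay. Compound 3 is therefore estimated at 8 nM (range 3 nM to 25 nM), a step of a 1.3-fold lower number from compound 2 to compound 3 (0.10 log units; within the scatter).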

Compound 3, half-maximal inhibitory concentration: 14 nM
Compound 3: middle estimate off by 1.8-fold (0.24 log units), on the low side; the measured number falls inside the stated range.
By their numbers in this assay, from the lowest: compounds 1, 2 and 3 (each within the scatter of the next, the first and the last beyond it).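

In this assay, for the compounds shown here, chloro in place of hydrogen gives a 1.4-fold higher number from compound 2 to compound 3 (0.15 log units; within the scatter) and so gives the first reading of a change on the phenoxy ring itself, with no shift beyond the scatter. Going by these compounds alone, the exchange of ethylsulfanyl for 2-chlorophenoxy gives a 2.4-fold higher number from compound 1 to compound 3 (0.38 log units; beyond the scatter) and is the first step to pass beyond the scatter, though only modestly. Nothing available bears on the cause of either step.

Still open, on these data alone, is whether a larger ortho group on the phenoxy ring, such as methoxy or an amine, would produce a step beyond the scatter from compound 2.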